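Compound 4: shortening the side chain of compound 3

The source may hold more compounds than are shown below. What is called first, only, known or untested is meant among the compounds shown, and "the series" means these compounds.

Going by the values given here, in a functional assay on HL-60 cells (Homo sapiens) for cytotoxicity, read by WST assay, with a stated time of 48 h (a lower number here means a stronger inhibitor, a higher number a weaker inhibitor), compound 3 (`CCCCC[C@H](C(C)C)C(c1ccc(O)c(OC)c1)c1ccc(O)c(OC)c1`) gives 9600 nM, the lowest number of the three measured so far. In the same read-out compound 2 (`COc1cc(C(c2ccc(O)c(OC)c2)[C@@H](C)C(C)C)ccc1O`) gives 20000 nM, and compound 1 (`COC[C@H](C(C)C)C(c1ccc(O)c(OC)c1)c1ccc(O)c(OC)c1`) gives 72000 nM.

Compound 4 (`COc1cc(C(c2ccc(O)c(OC)c2)[C@H](C)[C@H](C)CF)ccc1O`) carries 2-(fluoromethyl)-1-methylpropyl in place of 1-isopropylhexyl on a saturated chain carbon bound to two aromatic carbons.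

The nearest measured comparison is the modest step of a 2.1-fold lower number from compound 2 to compound 3 (0.32 log units; beyond the scatter), which also concerns 1-isopropylhexyl. The two steps involving the methoxymethyl-bearing chain are also modest: a 3.6-fold lower number from compound 1 to compound 2 (0.56 log units; beyond the scatter) and a 7.5-fold lower number from compound 1 to compound 3 (0.88 log units; beyond the scatter). Across these three compounds, the number falls in each step. Among the compounds with values here, no measured compound carries a fluoromethyl group, so the range stays wide.

A modest rise in the number is expected in this assay, with the estimated step being a 3.1-fold higher number from compound 3 to compound 4 (0.49 log units; beyond the scatter). Compound 4 is estimated at 30000 nM (expected range 12000 nM to 75000 nM).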

Compound 4, half-maximal inhibitory concentration: 56000 nM
Compound 4: middle estimate off by 1.9-fold (0.27 log units), on the low side, and the stated range covers the measured number.
By their numbers in this assay, from the lowest: compound 3; then compound 2; then compounds 4 and 1 (each within the scatter of the next).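

In this assay, replacing 1-isopropylhexyl with 2-(fluoromethyl)-1-methylpropyl on a saturated chain carbon bound to two aromatic carbons costs more than any difference between the two chains without a heteroatom, with a 5.8-fold higher number from compound 3 to compound 4 (0.77 log units; beyond the scatter) and a 2.8-fold higher number from compound 2 to compound 4 (0.45 log units; beyond the scatter). Against 1-(methoxymethyl)-2-methylpropyl the same group gives a 1.3-fold lower number from compound 1 to compound 4 (0.11 log units; within the scatter), so among these four compounds the chains carrying oxygen or fluorine, in compound 1 and compound 4, sit together at the high end, and no compound shown goes against this. No measurement available here accounts for this grouping.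

On these data alone, whether the higher number in compound 4 goes with the fluorine or with the shorter chain remains open. A 1-isopropylhexyl chain ending in fluoromethyl would separate the two, and a chain ending in an amine or a carboxylic acid would show whether the grouping extends to other heteroatoms.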